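Removing the acetyl from compound 3

The source may hold more compounds than are shown below. What is called first, only, known or untested is meant among the compounds shown, and "the series" means these compounds.

Compound 1 `COc1ccc(NC(=O)/C=C/C(=O)N2C/C(=C\c3ccc([N+](=O)[O-])cc3)C(=O)/C(=C/c3ccc([N+](=O)[O-])cc3)C2)cc1`: 760 nM
Compound 2 `CC(=O)c1ccc(NC(=O)/C=C/C(=O)N2C/C(=C\c3ccc([N+](=O)[O-])cc3)C(=O)/C(=C/c3ccc([N+](=O)[O-])cc3)C2)cc1`: 360 nM
Compound 3 `CC(=O)c1ccc(NC(=O)/C=C/C(=O)N2C/C(=C\c3ccccc3)C(=O)/C(=C/c3ccccc3)C2)cc1`: 1700 nM

Compound 3 stands at the top of the three numbers in a functional assay on CCRF-CEM cells (Homo sapiens) for cytotoxicity; on this read-out higher numbers stand for weaker inhibition and lower numbers for stronger inhibition; compound 1 sits a step below it and compound 2 lower still, both separations beyond the scatter. Compound 4 `O=C(/C=C/C(=O)N1C/C(=C\c2ccccc2)C(=O)/C(=C/c2ccccc2)C1)Nc1ccccc1` is compound 3 with hydrogen in place of acetyl on an aromatic carbon. Among the measured compounds shown here, the one measured step that touches this part of the molecule is a 2.1-fold lower number from compound 1 to compound 2 (0.32 log units; beyond the scatter), in which one group on that aromatic carbon replaced another; no measured step removes the group altogether, so the bearing is indirect. Because a 2.1-fold lower number from compound 1 to compound 2 (0.32 log units; beyond the scatter) went in favour of the acetyl-bearing member, taking the acetyl away is expected to move the number up rather than down, by a modest amount, though a change that stays within the scatter cannot be ruled out on this evidence. For compound 4 the expected step is therefore a 1.8-fold higher number from compound 3 to compound 4 (0.25 log units; within the scatter). Compound 4 is estimated at 3000 nM in this assay, with a range from 1200 nM to 7500 nM.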

Compound 4, half-maximal inhibitory concentration: 1100 nM
The estimate for compound 4 lay 2.7-fold (0.44 log units) above the measured number; measured number below the stated range.
By their numbers in this assay, from the lowest: compound 2; then compounds 1, 4 and 3 (each within the scatter of the next, the first and the last beyond it).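

On the phenyl-substituted core, in this assay, the step from 4-acetylphenyl to phenyl is a 1.5-fold lower number from compound 3 to compound 4 (0.19 log units; within the scatter) and, being within the scatter, gives no measurable difference between acetyl and hydrogen at this position para to a large group, so the acetyl is not required for the cytotoxicity of this pair. This adds something that a 2.1-fold lower number from compound 1 to compound 2 (0.32 log units; beyond the scatter) could not show, since that step compared acetyl with methoxy on the nitro-bearing core and left the effect of having no group on this aromatic carbon unread; its small advantage for acetyl over methoxy does not appear here as an advantage for acetyl over hydrogen, although the two steps differ in both the group compared and the core. The measurements shown give no basis for explaining why removing the acetyl has so little effect on this core.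

On these data alone, it remains open whether hydrogen on this carbon of the nitro-bearing core would match acetyl as it does in compound 4. Also open, as far as these compounds go, is whether an amine or a carboxylic acid at the same position would shift the number beyond the scatter.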